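Adding cyclopentyl to a polar parent compound

The source may hold more compounds than are shown below. What is called first, only, known or untested is meant among the compounds shown, and "the series" means these compounds.

Measured in a physicochemical assay for lipophilicity, using the shake flask method, at pH 7.4; a lower number here means a more polar compound, a higher number a more lipophilic compound:
Compound 1 `Cc1cc2c(N[C@H]3CC[C@H](N(C)C)CC3)ncnc2s1` gives 0.6
Compound 2 `CN(C)[C@H]1CC[C@H](Nc2ncnc3[nH]ccc23)CC1` gives -0.6
Compound 3 `CN(C)[C@H]1CC[C@H](Nc2ncnc3[nH]cc(C4CC4)c23)CC1` gives 0.9

Of these three, compound 2 has the lowest number, at -0.6. Compound 1 stands at 0.6, beyond the scatter from compound 2, and compound 3 is furthest away at 0.9.

Compound 4 `CN(C)[C@H]1CC[C@H](Nc2ncnc3[nH]cc(C4CCCC4)c23)CC1` has not yet been measured. It departs from compound 2 by one change, cyclopentyl in place of hydrogen on an aromatic carbon.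

For the measured compounds named here, only one measured step bears directly on this change, the replacement of hydrogen on an aromatic carbon by cyclopropyl. That step is large and lies beyond the scatter: a number 1.50 log units higher from compound 2 to compound 3 (beyond the scatter). Going by the values given here, a single step is thin evidence, and no measured compound shows how a cyclopentyl group behaves on this core. Even so, a large step in the same direction is expected in this assay, probably somewhat larger than the cyclopropyl step, as cyclopentyl is the bigger ring. The expected step is a number 2.30 log units higher from compound 2 to compound 4 (beyond the scatter). For compound 4 the estimated value is 1.7, with an expected range from 1.1 to 2.3.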

Compound 4, distribution coefficient: 1.7
For compound 4 middle estimate and measured number coincide at the digits printed; low and high end bracket the measured number.
By their numbers in this assay, from the lowest: compound 2; then compounds 1 and 3 (each within the scatter of the next); then compound 4.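

In this assay this aromatic carbon, on a five-membered aromatic ring of the shared core, can carry a second ring of carbon only with the number still rising: cyclopentyl in place of hydrogen gives a number 2.30 log units higher from compound 2 to compound 4 (beyond the scatter) and so goes past what cyclopropyl gave at the same place. The exchange of one ring for the other can now be read on its own, as a number 0.80 log units higher from compound 3 to compound 4 (beyond the scatter) on top of the first step, so the size of the rise here depends on which ring enters and not merely on hydrogen leaving; compounds 2, 3 and 4 follow this order, and none of the three goes against it. Nothing shown here gives a measured reason for this order, so the steps stand as observations only.

On these data alone, whether the rise continues with a larger ring such as cyclohexyl, or holds for an open chain such as isopropyl or for a ring carrying an amine, remains open. The compounds shown also leave open whether the same steps would hold on the core of compound 1, or what these rings do at other places on the shared core.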